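Halogen exchange on the aromatic group of the series

The compounds below may be only part of what the source reports. "The series", "measured", "known", "first", "only" and "open" are said of these compounds alone.

The compounds share one core and differ only in the aromatic group attached to it. Compound 1 `COc1cccc(Cc2cc(-c3cccs3)nn(CC(=O)Nc3ccc(F)cc3)c2=O)c1` carries thiophen-2-yl. In an assay on HL-60 cells for agonist activity at N-formyl peptide receptor 3 (Homo sapiens), read by calcium flux (on this read-out higher numbers stand for an effect only at larger amounts of compound and lower numbers for an effect already at smaller amounts), compound 1 gives only a limit, > 50000 nM. Compound 2 `COc1cccc(Cc2cc(-c3ccc(Cl)cc3)nn(CC(=O)Nc3ccc(F)cc3)c2=O)c1` carries 4-chlorophenyl instead. In this assay compound 2 likewise reaches only a limit, > 50000 nM. The step that the two limits leave unreadable from compound 1 to compound 2 therefore cannot be read, since both values sit at the limit of > 50000 nM in this assay, at which 2 of the 2 values shown sit. Compound 3 `COc1cccc(Cc2cc(-c3ccc(F)cc3)nn(CC(=O)Nc3ccc(F)cc3)c2=O)c1` differs from compound 2 by fluoro in place of chloro on an aromatic carbon. Among the compounds with values here, no measured step bears directly on this change, and the one step in hand is itself unreadable, so no direction can be drawn from it; with both measured compounds at the limit, the expectation for compound 3 is that it stays there as well. Compound 3 is estimated at 60000 nM, with a range of 20000 nM to 200000 nM. The step that the limit leaves unreadable from compound 2 to compound 3 is expected to be none beyond the scatter.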

Compound 3, half-maximal effective concentration: > 50000 nM
Compound 3 gave a limit, no number; the forecaster's own chance of this, stated with the estimate: 85%; the middle value lies beyond the limit too.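

No step among compound 1, compound 2 and compound 3 can be read in this assay, because all three values are limits: the limit of > 50000 nM in this assay, at which 3 of the 3 values shown sit.

The compounds shown leave open whether thiophen-2-yl, 4-chlorophenyl and 4-fluorophenyl differ at all in this read-out.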